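This account rests on a few compounds, and the source may have more. Where it says the series, first, only, none or still open, it means among the compounds named here.

Measured so far in a functional assay on KB cells (Homo sapiens) for cytotoxicity, read by MTT assay, with a stated time of 48 h; a higher number here means a weaker inhibitor, a lower number a stronger inhibitor:
- compound 1 `CCn1cc(-c2nc3ccccc3o2)c(=O)c2cc(F)c(N3CCNCC3)nc21`: 11700 nM
- compound 2 `CCn1cc(-c2nc3ccc(Cl)cc3[nH]2)c(=O)c2cc(F)c(N3CCNCC3)nc21`: 10300 nM

Not yet measured:
- compound 3 `CCn1cc(-c2nc3ccc(N)cc3[nH]2)c(=O)c2cc(F)c(N3CCNCC3)nc21`

In this assay, compound 2 gives 10300 nM and compound 1 gives 11700 nM. The two values lie within the scatter of each other, so neither compound can be ranked above the other.

The next comparison keeps everything in compound 2 except one substituent. Compound 3 carries amino in place of chloro on an aromatic carbon, on a six-membered aromatic ring of carbon only, part of a fused or bridged system of two rings.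

Among the compounds with values here, only one measured step bears on this change: a 1.1-fold lower number from compound 1 to compound 2 (0.06 log units; within the scatter). Within the data shown here, that step lies within the scatter, but it exchanged a whole group, and no measured pair tests the chloro alone. The evidence is therefore thin, and it gives no reason to expect a real shift in either direction. The expected step is a 1.1-fold lower number from compound 2 to compound 3 (0.06 log units; within the scatter), which is no change beyond the scatter in this assay. For compound 3 the estimated value is 9000 nM, with an expected range from 3500 nM to 25000 nM.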

Compound 3, half-maximal inhibitory concentration: 30100 nM
Estimate against measurement, compound 3: 3.3-fold (0.52 log units) below; the whole stated range lies below it.
By their numbers in this assay, from the lowest: compounds 2 and 1 (each within the scatter of the next); then compound 3.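

In this assay, within the data shown here, this place on the six-membered aromatic ring of carbon only is the first to respond to a change: amino in place of chloro gives a 2.9-fold higher number from compound 2 to compound 3 (0.47 log units; beyond the scatter) and so separates compound 3 from the two earlier compounds. The exchange of the whole group on the aromatic carbon of the core, now carrying amino, gives a 2.6-fold higher number from compound 1 to compound 3 (0.41 log units; beyond the scatter) in the same direction, whereas the chloro-bearing group gave only a 1.1-fold lower number from compound 1 to compound 2 (0.06 log units; within the scatter) and stayed within the scatter. Among these three compounds, then, the exchange of the group alone does not separate the values, and the nature of the single substituent does; the data offer no measured property that accounts for this shift.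

Going by these compounds, how a nitro group, a carboxylic acid or a plain hydrogen at this same place would compare with chloro and amino remains open, so no trend across substituents can be drawn from one pair. Also open, on these data alone, is whether an acetylated amine would keep the higher number of compound 3 or return to the range shared by compound 1 and compound 2.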